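The source may hold more compounds than are shown below. What is called first, only, known or untested is meant among the compounds shown, and "the series" means these compounds.

Measured so far in a functional assay on the whole organism (artery, strain albino) with Rattus norvegicus as the target, with a stated time of 60 min, at a dose of 10 mg/kg by the oral route; on this read-out lower numbers stand for less inhibition and higher numbers for more inhibition at the one dose given (going by the name of the read-out):
- compound 1 `COc1ccc(C2N=C(SCc3ccc(Cl)cc3)NC(C)=C2C(=O)Nc2ccc(F)cc2)cc1OC` gives 10.3%
- compound 2 `CC1=C(C(=O)Nc2ccc(F)cc2)C(c2ccc([N+](=O)[O-])cc2)N=C(SCc2ccc(F)cc2)N1` gives 10.8%
- compound 3 `CC1=C(C(=O)Nc2ccc(Br)cc2)C(c2ccc(Cl)cc2Cl)N=C(SCc2ccccc2Cl)N1` gives 11.8%

Compound 3 holds the highest of the three numbers, but its nearest neighbour, compound 2, lies within the scatter of it, and so does the furthest, compound 1. The three values therefore cannot be put in any order; on the evidence of this assay the series reads as flat at the dose used.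

Compound 4 `CC1=C(C(=O)Nc2ccc(Br)cc2)C(c2ccc(Cl)cc2Cl)N=C(SCc2ccc(F)cc2)N1` is the next member. It differs from compound 3 in one place: 4-fluorophenyl in place of 2-chlorophenyl on a saturated chain carbon bound to a sulfur. Among the compounds with values here, no pair of measured compounds isolates this change, so its effect is not known from a direct step. Compound 2 carries the same (4-fluorobenzyl)sulfanyl group, differing from compound 3 elsewhere as well, and its value in this assay sits within the scatter of the value of compound 3. Nothing among the shown compounds points to a step beyond the scatter for the change from compound 3 to compound 4 in this assay; the expected step is a number 0.8 percentage points lower from compound 3 to compound 4 (within the scatter), none beyond the scatter. Compound 4 is therefore estimated at 11%, with a range of 4% to 19%.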

Compound 4, a percentage reported as inhibition, in the whole organism at one dose (the size of the read-out at that dose, not a potency): 16.9%
Beside the measured number, compound 4's estimate is 5.9 percentage points below it; the measured number falls inside the stated range.
By their numbers in this assay, from the lowest: compounds 1, 2, 3 and 4 (each within the scatter of the next).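

Within the data shown here, the exchange of (2-chlorobenzyl)sulfanyl for (4-fluorobenzyl)sulfanyl gives the first direct reading at this position in this assay and amounts to a number 5.1 percentage points higher from compound 3 to compound 4 (within the scatter). Since this step stays within the scatter, the two compounds cannot be told apart at the one dose given, and the position accepts 4-fluorophenyl in place of 2-chlorophenyl without a readable difference. No measurement at hand offers an explanation for the size of this step.

Still open, from the compounds shown here alone, is whether any group at this position can move the read-out beyond the scatter, for instance a phenyl ring carrying a carboxylic acid or an amine, or a longer chain in place of the benzyl group. A single pair also cannot tell whether the same exchange reads alike on other members of the series.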